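A few compounds are considered here, and "the series" means these few. Any claim that something is new, unique, unknown or untested is made for them only; others in the source may bear on it.

Working notes on the series, on an ADME assay on microsomes from liver (Homo sapiens) for metabolic stability; on this read-out lower numbers stand for slow clearance and higher numbers for fast clearance.

Of the compounds shown here, three have numbers so far. Compound 1 `CN1C(=O)C2=C(C1=O)N(CC(=O)Nc1ccc(-c3cccnc3)nc1)CCC2` gives 11 mL.min-1.g-1 in this assay, the lowest of the three. For the measured compounds named here, compound 2 `CN1C(=O)C2=C(C1=O)N(CC(=O)Nc1ccc(-c3ccncc3)cc1)CCC2` gives 31 mL.min-1.g-1 and compound 3 `CN1C(=O)C2=C(C1=O)N(CC(=O)Nc1ccc(-c3cccnc3)cc1)CCC2` gives 37 mL.min-1.g-1; the one measured step, a 1.2-fold higher number from compound 2 to compound 3 (0.08 log units; within the scatter), lies within the scatter, so swapping the pyridin-4-yl for pyridin-3-yl on the outer ring left the number unchanged.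

Compound 4 `CN1C(=O)C2=C(C1=O)N(CC(=O)Nc1ccc(-c3ccccc3)nc1)CCC2` is the next to be measured. Relative to compound 1 the change is phenyl in place of pyridin-3-yl on an aromatic carbon. Going by the values given here, no measured step covers this exact swap; the step between compounds 2 and 3 concerns a shift of the ring nitrogen, not its removal, and so says little here. Among the compounds with values here, the only related comparison is that compound 1, whose central ring carries a nitrogen, sits well under compounds 2 and 3, whose central ring does not, which points to a higher number when a ring nitrogen is lost.

Compound 4 is therefore expected to show a step of a 2.3-fold higher number from compound 1 to compound 4 (0.36 log units; beyond the scatter), giving an estimated 25 mL.min-1.g-1 with a range of 12 mL.min-1.g-1 to 50 mL.min-1.g-1.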

Compound 4, intrinsic clearance in microsomes: 7 mL.min-1.g-1
Compound 4: the middle estimate sits 3.6-fold (0.55 log units) above what was measured; measured number below the stated range.
By their numbers in this assay, from the lowest: compounds 4 and 1 (each within the scatter of the next); then compounds 2 and 3 (each within the scatter of the next).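

In this assay, phenyl in place of pyridin-3-yl on an aromatic carbon, next to the ring nitrogen and para to a large group, gives a 1.6-fold lower number from compound 1 to compound 4 (0.20 log units; within the scatter), so removing the nitrogen of the outer ring at this position leaves the number within the scatter. Compounds 2 and 3 showed only a shift of that nitrogen, with a 1.2-fold higher number from compound 2 to compound 3 (0.08 log units; within the scatter); this pair adds that its full removal, in a compound whose ring bearing this group keeps its own nitrogen, also produces no step beyond the scatter. No measured evidence bears on why this swap behaves as it does.

Still open, going by these compounds, is what a non-aromatic group at this position, such as a morpholine, an amine or a carboxylic acid, would give. Also open, on these data alone, is whether the same swap stays within the scatter when made on compound 3, whose ring bearing this group has no nitrogen.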